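The compounds below may be only part of what the source reports. "The series", "measured", "known", "first", "only" and "open" are said of these compounds alone.

Compound 1 `CCC(CC)O[C@@H]1C=C(C(=O)O)C[C@H](NC(C)=N)[C@H]1NC(C)=O`: 1880 ng.h/mL
Compound 2 `CCOC(=O)C1=C[C@@H](OC(CC)CC)[C@H](NC(C)=O)[C@@H](N/C(C)=N/O)C1`: 13300 ng.h/mL

In an ADME assay on the whole organism (plasma, strain Sprague-Dawley) for pharmacokinetics, with Rattus norvegicus as the target, read by LC-MS, at a dose of 50 mg/kg by the intravenous route (on this read-out lower numbers stand for lower exposure and higher numbers for higher exposure at the dose given), compound 1 gives 1880 ng.h/mL and compound 2 gives 13300 ng.h/mL, the higher of the two, and the gap between them lies beyond the usual scatter. Compound 3 `CCOC(=O)C1=C[C@@H](OC(CC)CC)[C@H](NC(C)=O)[C@@H](N/C(N)=N\O)C1` keeps the core of compound 2 and carries one change, on an amine nitrogen: a group of 4 heavy atoms (1 carbon, 2 nitrogen, 1 oxygen; no ring) in place of a group of 4 heavy atoms (2 carbon, 1 nitrogen, 1 oxygen; no ring), on an amine nitrogen. Among the compounds with values here, no measured pair shows this change, so the expectation is cautious, with no shift beyond the scatter in either direction. The expected step is small, a 1.3-fold lower number from compound 2 to compound 3 (0.12 log units; within the scatter). For compound 3 the estimated value is 10000 ng.h/mL, with an expected range of 4000 ng.h/mL to 28000 ng.h/mL.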

Compound 3, area under the concentration-time curve: 317 ng.h/mL
Compound 3: middle estimate off by 32-fold (1.50 log units), on the high side, and the stated range ends above it.
By their numbers in this assay, from the lowest: compound 3; then compound 1; then compound 2.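

In this assay, replacing the group of 4 heavy atoms (2 carbon, 1 nitrogen, 1 oxygen) on the amine nitrogen with one of 4 heavy atoms (1 carbon, 2 nitrogen, 1 oxygen) gives a 42-fold lower number from compound 2 to compound 3 (1.62 log units; beyond the scatter) with the rest of the molecule unchanged. Exposure at this position therefore responds strongly to a change that leaves the group's size unaltered, something compound 1 and compound 2 could not show because they differ in more than one place.

From the compounds shown here alone, how a longer chain or a plain amine on this nitrogen would behave remains open. Nothing available here explains the drop.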